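The source may report more compounds than this note shows. Statements on the series, on what has been measured and on what is new or still open speak of the compounds shown alone.

Of the compounds shown here, three that share one core have been tested in a functional assay on AN3-CA cells (Homo sapiens) for antiproliferative activity, read by MTT assay, with a stated time of 72 h; a higher number here means a weaker inhibitor, a lower number a stronger inhibitor. Compound 1 `O=C(Nc1ccc(Cl)c(-c2nnc3c(Cl)cccn23)c1)c1ccc(C(F)(F)F)cc1Cl` gives > 100000 nM, which is a limit of the assay and not a number. Compound 2 `O=C(Nc1ccc(Cl)c(-c2nnc3c(Cl)cccn23)c1)c1ccc(F)cc1Cl` gives > 100000 nM, again a limit. Compound 3 `O=C(Nc1ccc(Cl)c(-c2nnc3c(Cl)cccn23)c1)c1cccnc1` gives > 100000 nM, also a limit. Compound 2 therefore has no number of its own and no rank among the three, which all sit at the limit of > 100000 nM in this assay, at which 3 of the 3 values shown sit.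

Compound 4 `O=C(Nc1ccc(Cl)c(-c2nnc3c(Cl)cccn23)c1)c1ccc(Cl)cc1Cl` differs from compound 2 by a single swap: chloro in place of fluoro on an aromatic carbon. Chloro takes the place of fluoro on an aromatic carbon, so 2-chloro-4-fluorophenyl becomes 2,4-dichlorophenyl.

For the measured compounds named here, two measured steps bear on this swap. One is a step that the two limits leave unreadable from compound 1 to compound 2, with fluoro in place of trifluoromethyl on the same ring carbon that changes here. The other is a step that the two limits leave unreadable from compound 2 to compound 3, with pyridin-3-yl in place of the whole 2-chloro-4-fluorophenyl group. Neither step has a readable size, and neither change produced a number in this assay. These steps point to no direction, so no change beyond the usual scatter is expected, and another limit is the likeliest report. The expected result is a number no higher from compound 2 to compound 4 (the limit leaves the size open). For compound 4 the estimate is 100000 nM, with an expected range from 40000 nM to 200000 nM.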

Compound 4, half-maximal inhibitory concentration: 84800 nM
Beside the measured number, compound 4's estimate is 1.2-fold (0.07 log units) above it, and the stated range covers the measured number.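

Going from 2-chloro-4-fluorophenyl to 2,4-dichlorophenyl gives the only real number among the four compounds in this assay, while the others stay at a limit of the assay and not at a number: the limit of > 100000 nM in this assay, at which 3 of the 4 values shown sit. Read against those limits, the swap at this ring carbon, para to a large group, gives an at least 1.1-fold lower number from compound 2 to compound 4 (0.07 log units; that floor lies within the scatter), and the two other comparisons give an at least 1.1-fold lower number from compound 3 to compound 4 (0.07 log units; that floor lies within the scatter) and an at least 1.1-fold lower number from compound 1 to compound 4 (0.07 log units; that floor lies within the scatter). As far as these compounds go, each of these is only a floor, so the true sizes remain unknown: chloro at this position brings the compound into the range the assay can read, but that does not establish a real gain over fluoro, trifluoromethyl or the pyridin-3-yl group.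

The steps among compound 1, compound 2 and compound 3 cannot be read, so those three have no order among themselves. Still open, from the compounds shown here alone, is what a bromo group, a methoxy group or an amine would give at this same ring carbon, and whether any such group would give a number clearly beyond the scatter from compound 4.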